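Halogen position swap on a benzyl ether agonist

The compounds below may be only part of what the source reports. "The series", "measured", "known", "first", "only" and "open" are said of these compounds alone.

Compound 1 `Cc1nn(-c2ncnc3nc[nH]c23)c2c1C(C(=O)NCc1ccccc1)CC(=O)N2`: 5 nM
Compound 2 `Cc1nn(-c2ncnc3nc[nH]c23)c2c1C(OCc1ccc(F)cc1)CC(=O)N2`: 1 nM

Among the compounds with values here, in a functional assay on HEK293 cells for agonist activity at G-protein coupled receptor 39 (Homo sapiens), read by scintillation proximity assay and inositol phosphate accumulation, with a stated time of 75 min, in the presence of a further agent that is not named here (on this read-out lower numbers stand for an effect already at smaller amounts and higher numbers for an effect only at larger amounts of compound), compound 2 gives the lower of the two measured numbers, and the one measured step, a 5.0-fold lower number from compound 1 to compound 2 (0.70 log units; beyond the scatter), concerns the link to the benzyl group rather than the ring itself. Compound 3 `Cc1nn(-c2ncnc3nc[nH]c23)c2c1C(OCc1ccccc1Cl)CC(=O)N2` carries the change (2-chlorophenyl in place of 4-fluorophenyl on a saturated chain carbon bound to an oxygen on a saturated carbon). Within the data shown here, no measured step bears on moving or exchanging a halogen on that ring, so nothing here suggests a shift beyond the scatter in this assay. Compound 3 is expected near 1.5 nM, within 0.4 nM to 6 nM, which is an estimated step of a 1.5-fold higher number from compound 2 to compound 3 (0.18 log units; within the scatter).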

Compound 3, half-maximal effective concentration: 2 nM
The estimate for compound 3 lay 1.3-fold (0.12 log units) below the measured number; low and high end bracket the measured number.
By their numbers in this assay, from the lowest: compounds 2 and 3 (each within the scatter of the next); then compound 1.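

In this assay, within the data shown here, the 2-chlorophenyl group does as well as 4-fluorophenyl at this place (a 2.0-fold higher number from compound 2 to compound 3 (0.30 log units; within the scatter)), so this ether accepts a different halogen at a different ring position, though the single change cannot separate those two differences. A second benzyl ether also gives a lower number than the benzylcarbamoyl compound (a 2.5-fold lower number from compound 1 to compound 3 (0.40 log units; beyond the scatter)). Nothing measured here explains either result. As far as these compounds go, whether a methoxy group or an amine on the phenyl ring would keep numbers this low remains open, as does the effect of a longer chain in place of the benzyl group.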